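Exchanging the Azide for Methylamine on the Oxazolidinone Side Chain

The compounds below may be only part of what the source reports. "The series", "measured", "known", "first", "only" and "open" are said of these compounds alone.

Of the compounds shown here, two have been measured in an assay for inhibition of Amine oxidase [flavin-containing] B (Bos taurus), read by fluorescence, with a stated time of 30 min; on this read-out higher numbers stand for weaker inhibition and lower numbers for stronger inhibition. Compound 1 `CCn1ccc(N2C[C@H](CO)OC2=O)c1` gives 300 nM. Compound 2 `Cn1ccc(N2C[C@H](CN=[N+]=[N-])OC2=O)c1` gives 360000 nM, the highest of the two numbers and therefore the weaker inhibitor of the pair; the two compounds differ in more than one place, so their values can only be compared, not traced to a single change. Compound 3 `CNC[C@H]1CN(c2ccn(C)c2)C(=O)O1` has not yet been measured in this assay. It differs from compound 2 in one place: methylamino in place of azido on a saturated chain carbon bound to a saturated ring carbon. Since compound 2 sits so far above compound 1, there is much room for a lower number, but nothing measured shows how this particular exchange behaves. The expected step is a moderate move toward stronger inhibition, a 12-fold lower number from compound 2 to compound 3 (1.08 log units; beyond the scatter), well beyond the scatter but still leaving compound 3 weaker than compound 1. Compound 3 is estimated at 30000 nM, with a plausible range from 3000 nM to 300000 nM.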

Compound 3, inhibition constant: > 100000 nM
Compound 3 gave a limit, no number; the forecaster's own chance of this, stated with the estimate: 15%; middle value at least 3.3-fold (0.52 log units) away from the limit.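

Compound 3 gave only a limit, not a number, so the step from compound 2 to compound 3 cannot be read: the limit of > 100000 nM in this assay, at which 1 of the 3 values shown sits. The compounds shown leave open whether methylamino in place of azido strengthens inhibition, weakens it or leaves it unchanged.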